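This account rests on a few compounds, and the source may have more. Where it says the series, first, only, none or still open, it means among the compounds named here.

Three analogues of the shared core have been run in a functional assay on KB cells (Homo sapiens) for cytotoxicity, read by MTT assay, with a stated time of 3 days; on this read-out lower numbers stand for stronger inhibition and higher numbers for weaker inhibition. Compound 1 `C=C1c2c(C)nc(OC)c(C#N)c2N=CN1CC` gives > 50000 nM, a limit of the assay rather than a number. Compound 2 `C=C1c2c(C)nc(OC)c(C#N)c2N=CN1Cc1ccco1` gives > 50000 nM, again only a limit. Compound 3 `C=C1c2c(C)nc(OC)c(C#N)c2N=CN1Cc1ccccc1` gives > 50000 nM, which is likewise a limit and not a number. All three values sit at the limit of > 50000 nM in this assay, at which 3 of the 3 values shown sit, so the steps a step that the two limits leave unreadable from compound 1 to compound 2, a step that the two limits leave unreadable from compound 1 to compound 3 and a step that the two limits leave unreadable from compound 2 to compound 3 have no readable size. Compound 3 therefore stands on no number at all in this assay, only on the limit shared with compounds 1 and 2.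

Compound 4 `C=C1c2c(C)nc(OC)c(C#N)c2N=CN1Cc1cccc(C)c1` differs from compound 3 by methyl in place of hydrogen on an aromatic carbon. Every measured step bears on it only in the sense that none leaves the limit, and none shows a direction or a size; nothing in the series points to a readable change. The step expected is a number no higher from compound 3 to compound 4 (the limit leaves the size open), none beyond the scatter. Compound 4 is accordingly expected to come out at about 50000 nM in this assay, somewhere between 15000 nM and 150000 nM, and most probably to be reported once more as a limit rather than a number.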

Compound 4, half-maximal inhibitory concentration: 37000 nM
Beside the measured number, compound 4's estimate is 1.4-fold (0.13 log units) above it; the range from low to high includes it.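

In this assay compound 4 is the only analogue shown that gives a number rather than a limit, while the others stay at the limit: the limit of > 50000 nM in this assay, at which 3 of the 4 values shown sit.

Methyl in place of hydrogen on an aromatic carbon, meta to a large group, therefore gives the series its only readable steps, with an at least 1.3-fold lower number from compound 3 to compound 4 (0.13 log units; that floor lies within the scatter), though this is a floor and not a measured size. Exchanging furan-2-yl for 3-methylphenyl gives an at least 1.3-fold lower number from compound 2 to compound 4 (0.13 log units; that floor lies within the scatter), and exchanging methyl for 3-methylphenyl gives an at least 1.3-fold lower number from compound 1 to compound 4 (0.13 log units; that floor lies within the scatter), both again only floors.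

The steps among compound 1, compound 2 and compound 3 cannot be read. Going by these compounds, whether an ethyl group, a methoxy group, an amine or a carboxylic acid in place of this methyl would give a number, and of what size, remains open.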